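The source may hold more compounds than are shown below. What is called first, only, known or untested is meant among the compounds shown, and "the series" means these compounds.

Measured in a functional assay on HCT-116 cells (Homo sapiens) for cytotoxicity, read by MTT assay, with a stated time of 72 h; a higher number here means a weaker inhibitor, a lower number a stronger inhibitor:
- compound 1 `NCCCNc1c(C(=O)NCc2ccc(F)cc2)nc(Br)c2cccnc12`: > 20000 nM (a limit)
- compound 2 `N[C@H]1CC[C@H](Nc2c(C(=O)NCc3ccc(F)cc3)nc(Br)c3cccnc23)CC1`: 7000 nM
- compound 3 `O=C(NCc1ccc(F)cc1)c1nc(Br)c2cccnc2c1N1CCNCC1`: > 10000 nM (a limit)

The result for compound 3 is a limit, > 10000 nM, so it gives no exact starting number. Compound 4 `CNCCCNc1c(C(=O)NCc2ccc(F)cc2)nc(Br)c2cccnc12` differs from compound 3 by one change, with (3-(methylamino)propyl)amino in place of piperazin-1-yl on an aromatic carbon.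

The closest measured comparison is a step that the two limits leave unreadable from compound 1 to compound 3, which links piperazin-1-yl with (3-aminopropyl)amino but gives no usable size. The other step to compound 3 is an at least 1.4-fold higher number from compound 2 to compound 3 (0.15 log units; that floor lies within the scatter). Neither supports a clear shift, so no step beyond the scatter is expected in this assay, and another limit may well be reported.

The expected change is a step that the limit leaves unreadable from compound 3 to compound 4. Compound 4 is estimated at 15000 nM, with an expected range of 6000 nM to 40000 nM.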

Compound 4, half-maximal inhibitory concentration: 9000 nM
Compound 4: middle estimate off by 1.7-fold (0.22 log units), on the high side; measured number inside the range.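

In this assay, swapping the ring for the open chain at this position gives a measured number in place of a limit, yet an at least 1.1-fold lower number from compound 3 to compound 4 (0.04 log units; that floor lies within the scatter) is a step whose floor lies within the scatter, so no clear gain is shown. Methyl in place of hydrogen on the amine nitrogen gives an at least 2.2-fold lower number from compound 1 to compound 4 (0.34 log units; beyond the scatter) and so lifts the chain to the level of the 4-aminocyclohexyl group, though that step starts from a limit: the limit of > 20000 nM in this assay, at which 1 of the 4 values shown sits. The comparison with that group gives a 1.3-fold higher number from compound 2 to compound 4 (0.11 log units; within the scatter) and shows no separation between the two.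

Still open, going by these compounds, is what a dimethylamino group at the end of the chain, or a longer chain, would do at this position.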